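Cytotoxicity in Vero cells across a benzyl ether series

This account rests on a few compounds, and the source may have more. Where it says the series, first, only, none or still open, it means among the compounds named here.

Measured so far:
- compound 1, `CCOC(=O)c1cc(-c2cccc(OCc3cccc(F)c3F)c2)on1`: > 128000 nM
- compound 2, `CCOC(=O)c1cc(-c2cccc(OCc3ccc(Cl)c(Cl)c3)c2)on1`: "not determined" (no result reported)

Compound 1 was tested in an ADME assay on Vero cells (Chlorocebus sabaeus) for cytotoxicity, with a stated time of 72 h (a higher number here means a weaker inhibitor, a lower number a stronger inhibitor), and the result is a limit of the assay rather than a number: in this assay compound 1 gives > 128000 nM. For compound 2 no result was reported in this assay. Where compound 2 stands therefore rests on the one value shown beside it, which is the limit of > 128000 nM in this assay, at which 1 of the 2 values shown sits, a limit and not a number.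

Compound 3, `CCOC(=O)c1cc(-c2cccc(OCc3cc(F)cc(F)c3)c2)on1`, has not yet been measured in this assay. It differs from compound 2 in one place: 3,5-difluorophenyl in place of 3,4-dichlorophenyl on a saturated chain carbon bound to an oxygen on an aromatic ring. Among the compounds with values here, no step between measured compounds is available for comparison, so there is nothing in the numbers that points to a shift in either direction, and no step beyond the usual scatter is expected in this assay from compound 2 to compound 3.

Given that compound 1 reached only the limit of this assay, compound 3 is expected to give roughly 128000 nM in this assay, within a range of 50000 nM to 300000 nM, most likely again reported as a limit.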

Compound 3, half-maximal inhibitory concentration: > 128000 nM
Compound 3: a limit, no number; the forecaster's own chance of this, stated with the estimate: 80%; the middle value sits exactly at the limit.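

Compound 1 and compound 3 sit at the same limit in this assay, so no step between them can be read: the limit of > 128000 nM in this assay, at which 2 of the 3 values shown sit.

The compounds shown leave open whether exchanging the 2,3-difluorophenyl, 3,5-difluorophenyl or 3,4-dichlorophenyl group changes the result in this assay at all, as none of them has a number there.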